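The compounds below may be only part of what the source reports. "The series", "measured", "known", "first", "only" and "open" are said of these compounds alone.

Measured in a functional assay on MCF7 cells (Homo sapiens) for antiproliferative activity, read by MTT assay, with a stated time of 72 h; on this read-out lower numbers stand for stronger inhibition and higher numbers for weaker inhibition:
- compound 1 `CCOc1ccc(-c2ncnn2-c2cc(OC)c(OC)c(OC)c2)cc1`: 50 nM
- compound 2 `COc1cc(-n2ncnc2-c2ccc(OC(C)C)cc2)cc(OC)c1OC`: 610 nM
- compound 3 `COc1cc(-n2ncnc2-c2cccc(Cl)c2)cc(OC)c1OC`: > 10000 nM (a limit, not a number)

Compound 3 has no numerical value, and its position is known only as the limit of > 10000 nM in this assay, at which 1 of the 3 values shown sits.

Compound 4 `COc1cc(-n2ncnc2-c2ccc(SC)cc2)cc(OC)c1OC` carries 4-(methylsulfanyl)phenyl in place of 3-chlorophenyl on an aromatic carbon.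

Going by the values given here, no measured step covers this exchange directly. Among the compounds with values here, the only measured step is a 12-fold higher number from compound 1 to compound 2 (1.09 log units; beyond the scatter), a large change from a single added methyl on the ether chain of the aryl group. It shows that small edits to that group can move the read-out well beyond the scatter, but it gives no direct size for the exchange at hand.

The expectation rests mainly on the two measured ethers. Like compound 1 at 50 nM and compound 2 at 610 nM, compound 4 has a short chain on its aryl group, though attached through sulfur rather than oxygen. A large step towards stronger inhibition in this assay is therefore expected, although a second limit cannot be excluded.

The expected step is an at least 50-fold lower number from compound 3 to compound 4 (1.69 log units; beyond the scatter).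

For compound 4 the estimate is 200 nM, with an expected range of 30 nM to 2000 nM.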

Compound 4, half-maximal inhibitory concentration: 390 nM
Estimate against measurement, compound 4: 2.0-fold (0.29 log units) below; the measured number falls inside the stated range.
By their numbers in this assay, from the lowest: compound 1; then compounds 4 and 2 (each within the scatter of the next). At a limit, above all of these: compound 3.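

In this assay, 4-(methylsulfanyl)phenyl in place of 3-chlorophenyl gives an at least 25-fold lower number from compound 3 to compound 4 (1.40 log units; beyond the scatter), which shows that this position on the shared core can return to a measurable read-out with an aryl group carrying a sulfur-linked chain, not only an oxygen-linked one. The value of compound 3 is a limit and not a number, so this step holds only as a bound: the limit of > 10000 nM in this assay, at which 1 of the 4 values shown sits. Methylsulfanyl in place of isopropoxy gives a 1.6-fold lower number from compound 2 to compound 4 (0.19 log units; within the scatter), within the scatter, whereas methylsulfanyl in place of ethoxy gives a 7.8-fold higher number from compound 1 to compound 4 (0.89 log units; beyond the scatter), beyond the scatter, so the sulfur-linked group is on a level with the isopropoxy group but does not match the ethoxy group.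

The compounds shown do not tell whether the limit of compound 3 goes with the chlorine itself, with where it sits on the ring, or with the lack of a chain there. As far as these compounds go, how a methoxy group, a dimethylamino group or a longer chain such as butoxy would stand against ethoxy and methylsulfanyl on this aryl group also stays open.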